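This account rests on a few compounds, and the source may have more. Where it says the series, first, only, none or still open, it means among the compounds named here.

The measured compounds:
compound 1, `COc1ccccc1/C=C/C(=O)c1nc2ccccc2[nH]1`, with 41300 nM;
compound 2, `O=C(/C=C/c1ccccc1)c1nc2ccccc2[nH]1`, with 39800 nM;
compound 3, `O=C(/C=C/c1cccc(Cl)c1)c1nc2ccccc2o1`.

Compound 1 and compound 2 share a core and differ by a 1.0-fold lower number from compound 1 to compound 2 (0.02 log units; within the scatter), a change that stays within the scatter. Compound 3 carries a different core, and in a functional assay on MCF7 cells (Homo sapiens) for antiproliferative activity, read by MTT assay, with a stated time of 48 h (on this read-out higher numbers stand for weaker inhibition and lower numbers for stronger inhibition), compound 3 gives only a limit of the assay, > 100000 nM. This is the limit of > 100000 nM in this assay, at which 1 of the 3 values shown sits, so compound 3 stands not at a number but at the edge of what this assay reports, and nothing more can be said of its place among the values shown.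

Compound 4, `COc1cccc(/C=C/C(=O)c2nc3ccccc3o2)c1`, keeps the core of compound 3 and changes it by methoxy in place of chloro on an aromatic carbon. Going by the values given here, no measured step exchanges chloro for methoxy; the one step that touches a methoxy group, the step from compound 1 to compound 2, is within the scatter and sits on the other core. On that thin ground compound 4 is expected to move little from compound 3, with a number no higher from compound 3 to compound 4 (the limit leaves the size open) being the estimated step and a fair chance that this assay again returns only a limit. Compound 4 is therefore estimated at 100000 nM, within the range 40000 nM to 250000 nM.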

Compound 4, half-maximal inhibitory concentration: > 100000 nM
Compound 4: no number, only a limit (the forecaster's own chance of this, stated with the estimate: 55%); the middle value sits exactly at the limit.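

In this assay compound 4 gives > 100000 nM, which is a limit and not a number. Going by these compounds alone, no step between compound 3 and compound 4 can be read, because both stand at a limit: the limit of > 100000 nM in this assay, at which 2 of the 4 values shown sit. The compounds shown leave open whether methoxy or chloro on the core of compound 3 gives the lower number.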